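Swapping Bromo for Chloro on the Sulfonamide Aryl Ring

A few compounds are considered here, and "the series" means these few. Any claim that something is new, unique, unknown or untested is made for them only; others in the source may bear on it.

Compound 1 `Cc1ccc(NS(=O)(=O)C2CCCCC2=O)cc1` gives 32.1%
Compound 2 `O=C1CCCCC1S(=O)(=O)Nc1ccccc1Br` gives 29.6%
Compound 3 `O=C1CCCCC1S(=O)(=O)Nc1ccc(Cl)c(Cl)c1` gives 5.54%

These three compounds share a common core and were measured in a functional assay on BGC-823 cells (Homo sapiens) for antiproliferative activity, read by sulforhodamine B assay, tested at 100 ug/mL; on this read-out higher numbers stand for more inhibition at the one concentration tested (going by the name of the read-out) and lower numbers for less inhibition. Compound 2 sits close to compound 1, a gap within the usual scatter of repeated runs, so the two cannot be ranked against each other; compound 3 lies far lower, a gap beyond that scatter. Compound 4 `O=C1CCCCC1S(=O)(=O)Nc1ccccc1Cl` has not yet been measured. It differs from compound 2 in one place: chloro in place of bromo on an aromatic carbon. Among the measured compounds shown here, no measured pair shows this exact exchange, so the step must be judged from the structural change alone. In this assay only a small step is expected, a number 1.6 percentage points lower from compound 2 to compound 4 (within the scatter), not beyond the scatter in either direction. Compound 4 is therefore estimated at 28%, with a range from 13% to 43%.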

Compound 4, a percentage reported as inhibition, at one concentration (the size of the read-out at that concentration, not a potency): 29.2%
Beside the measured number, compound 4's estimate is 1.2 percentage points below it; measured number inside the range.
By their numbers in this assay, from the lowest: compound 3; then compounds 4, 2 and 1 (each within the scatter of the next).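

In this assay the exchange of chloro in place of bromo, on an aromatic carbon ortho to a large group, comes to a number 0.4 percentage points lower from compound 2 to compound 4 (within the scatter) and so the two halogens cannot be told apart at this position. Among the compounds shown here, this is the first pair that differs in one place, so it is the first direct reading of a single change. Nothing measured here explains the result.

Going by these compounds, whether an amine or a carboxylic acid at this position would give a similar number remains open. So does whether the same halogen exchange elsewhere on the ring would behave alike.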